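This account rests on a few compounds, and the source may have more. Where it says the series, first, only, none or still open, it means among the compounds named here.

Measured in a functional assay on OCI-Ly3 cells (Homo sapiens) for inhibition, read by CellTiter-Glo, with stated times of 48 h and 96 h; a higher number here means a weaker inhibitor of growth, a lower number a stronger inhibitor of growth:
- compound 1 `CC(C)[C@H](NC(=O)c1cccc(Br)c1)C(=O)N1CCC[C@H]1C(=O)N[C@@H](CCCNC(=N)N)C(=O)CF`: 530 nM
- compound 2 `CC(C)[C@H](NC(=O)c1ccc(C#N)cc1)C(=O)N1CCC[C@H]1C(=O)N[C@@H](CCCNC(=N)N)C(=O)CF`: 6660 nM

Of these two compounds, compound 2 has the higher number at 6660 nM, which makes it the weaker inhibitor of growth. The next change starts from compound 2 and leads to compound 3 `CC(C)[C@H](NC(=O)c1ccc(C(F)(F)F)cc1)C(=O)N1CCC[C@H]1C(=O)N[C@@H](CCCNC(=N)N)C(=O)CF`: trifluoromethyl in place of cyano on an aromatic carbon.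

For the measured compounds named here, only one measured step bears on this change. The step of a 13-fold higher number from compound 1 to compound 2 (1.10 log units; beyond the scatter) is large and lies beyond the scatter. Going by the values given here, it exchanges 3-bromophenyl for 4-cyanophenyl, so the group and its place change together, and no measured compound carries trifluoromethyl. The evidence is therefore indirect. Compound 1 at 530 nM shows that a much lower number is possible with this shared core, and a moderate move in that direction is expected in this assay, smaller in size than a 13-fold higher number from compound 1 to compound 2 (1.10 log units; beyond the scatter). The expected step is a 3.3-fold lower number from compound 2 to compound 3 (0.52 log units; beyond the scatter), though its range reaches back to the scatter. For compound 3 the estimated value is 2000 nM, with an expected range of 500 nM to 7000 nM.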

Compound 3, concentration for 50% growth inhibition: 120 nM
Compound 3: middle estimate off by 17-fold (1.22 log units), on the high side; the measured number lies below the stated range.
By their numbers in this assay, from the lowest: compound 3; then compound 1; then compound 2.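

In this assay, with the place on the ring held constant, trifluoromethyl in place of cyano gives a 56-fold lower number from compound 2 to compound 3 (1.74 log units; beyond the scatter). The earlier step changed the group and its place together, whereas this one shows that the group alone, on an aromatic carbon para to a large group, can move the number by a large margin. The second new step, a 4.4-fold lower number from compound 1 to compound 3 (0.65 log units; beyond the scatter), is modest but beyond the scatter, so 4-(trifluoromethyl)phenyl gives the lowest number of the three, although this step again changes the group and its place together, and nothing measured here explains either step.

The compounds shown leave open how other groups on this same aromatic carbon would read, such as methyl, methoxy or a chlorine atom, and so whether trifluoromethyl is unusual there or cyano is. They also leave open how much of the gap between the two aryl groups belongs to the place on the ring, which a bromine atom on the carbon that carries trifluoromethyl in compound 3 would help to separate.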